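Heteroaryl swap at the para position and cytotoxicity

The compounds below may be only part of what the source reports. "The series", "measured", "known", "first", "only" and "open" are said of these compounds alone.

Three compounds share a core and differ only in the aryl group that sits para to a large group on the difluorinated ring: compound 1 `Cc1cnc(Nc2ccc(C#N)cc2)nc1Nc1c(F)cc(-c2ccco2)cc1F`, compound 2 `Cc1cnc(Nc2ccc(C#N)cc2)nc1Nc1c(F)cc(-c2ccoc2)cc1F` and compound 3 `Cc1cnc(Nc2ccc(C#N)cc2)nc1Nc1c(F)cc(-c2ccsc2)cc1F`. In a toxicity assay on MT4 cells (Homo sapiens) for cytotoxicity, read by MTT assay, with a stated time of 5 days (on this read-out higher numbers stand for lower toxicity in this test and lower numbers for higher toxicity in this test), compound 1 gives 8100 nM, compound 2 gives 4200 nM and compound 3 gives 261000 nM. Compound 3 stands highest of the three; the step of a 32-fold higher number from compound 1 to compound 3 (1.51 log units; beyond the scatter) and the step of a 62-fold higher number from compound 2 to compound 3 (1.79 log units; beyond the scatter) are both large and beyond the scatter, whereas a 1.9-fold lower number from compound 1 to compound 2 (0.29 log units; within the scatter) stays within the scatter.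

Compound 4 `Cc1cnc(Nc2ccc(C#N)cc2)nc1Nc1c(F)cc(-c2cc(F)nc(F)c2)cc1F` is not yet measured in this assay. Its difference from compound 3 is 2,6-difluoropyridin-4-yl in place of thiophen-3-yl on an aromatic carbon. Going by the values given here, no measured step involves a six-membered aromatic ring at this position, so the two large steps ending at compound 3 are the only guide; they show that exchanging the heteroaryl group here can move the number widely, and that compound 3 is the outlier among the three. A step of some size toward the lower numbers of compound 1 and compound 2 is therefore expected for compound 4, but its direction and size are uncertain. The expected step from compound 3 is an 8.7-fold lower number from compound 3 to compound 4 (0.94 log units; beyond the scatter). Compound 4 is estimated at 30000 nM, with a range from 5000 nM to 200000 nM.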

Compound 4, half-maximal cytotoxic concentration: 103000 nM
Compound 4: middle estimate off by 3.4-fold (0.54 log units), on the low side; the measured number falls inside the stated range.
By their numbers in this assay, from the lowest: compounds 2 and 1 (each within the scatter of the next); then compound 4; then compound 3.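

In this assay, the first six-membered aromatic ring at this position, 2,6-difluoropyridin-4-yl, lands near the high end of the series, with a 13-fold higher number from compound 1 to compound 4 (1.10 log units; beyond the scatter) and a 25-fold higher number from compound 2 to compound 4 (1.39 log units; beyond the scatter) both large, while a 2.5-fold lower number from compound 3 to compound 4 (0.40 log units; beyond the scatter) is only modest yet still beyond the scatter. High numbers at this place on the ring are therefore not unique to thiophen-3-yl: compound 3 and compound 4 both stand well above the furan pair, compound 1 and compound 2, and the change of ring size alone does not bring the number down to the furan level. No evidence on the origin of these differences is at hand.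

From the compounds shown here alone, whether the number of compound 4 follows the six-membered ring itself or its fluoro groups remains open, and a plain phenyl or pyridin-4-yl group would separate the two. Also open, going by these compounds, is whether thiophen-2-yl would track thiophen-3-yl, and how a non-aromatic group at this place, such as an amine, a carboxylic acid or a longer chain, would read in this test.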